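Mirror image of an inactive compound: what to expect

The compounds below may be only part of what the source reports. "The series", "measured", "known", "first", "only" and "open" are said of these compounds alone.

- compound 1 `CCOC(=O)[C@@]1(C(=O)Nc2ccccc2Cl)C[C@@H]1c1cc(OC)c(OC)c(OC)c1` gives > 100000 nM
- compound 2 `CCOC(=O)[C@]1(C(=O)Nc2ccccc2Cl)C[C@@H]1c1cc(OC)c(OC)c(OC)c1` gives > 100000 nM

These results come from a functional assay on HeLa cells (Homo sapiens) for cytotoxicity, read by MTT assay, with a stated time of 48 h (a higher number here means a weaker inhibitor, a lower number a stronger inhibitor), and each one is a limit of the assay, not a number. Compound 2 therefore has a limit to its name and no measured potency.

The next compound is compound 3 `CCOC(=O)[C@@]1(C(=O)Nc2ccccc2Cl)C[C@H]1c1cc(OC)c(OC)c(OC)c1` and the change is this: the two compounds have the same atoms and bonds and differ only in configuration as drawn: 2 of 2 stereo elements differ (all stereocentres are inverted: mirror images); a stereocentre at a saturated ring carbon is drawn R in compound 2 and S in compound 3; a stereocentre at a saturated ring carbon is drawn R in compound 2 and S in compound 3 so the two are mirror images.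

Going by the values given here, one measured step bears on this change: a step that the two limits leave unreadable from compound 1 to compound 2 where only one of the two stereocentres differs. Two facts frame that step: the limit of > 100000 nM in this assay, at which 2 of the 2 values shown sit, and also the fact that compounds 1 and 2 differ only in the configuration as drawn which together show that no configuration tested so far has given a number. Inverting both stereocentres is untested, and these limits offer no size or direction for a step. Compound 3 is expected to stay at a limit in this assay just as compound 2 did. The expected step, with no direction foreseen, is a step that the limit leaves unreadable from compound 2 to compound 3 as an estimate only. For compound 3 the estimated value is 120000 nM with an expected range from 40000 nM to 300000 nM as its upper end.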

Compound 3, half-maximal inhibitory concentration: 14400 nM
For compound 3 the middle estimate is 8.3-fold (0.92 log units) above the measured one; measured number outside the range, below it.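

In this assay, going by these compounds alone, compound 3 is the first of these stereoisomers to give a readable number, and the mirror-image pair shows an at least 6.9-fold lower number from compound 2 to compound 3 (0.84 log units; beyond the scatter) with no atom or bond changed. Inverting a single stereocentre also reaches that number, with an at least 6.9-fold lower number from compound 1 to compound 3 (0.84 log units; beyond the scatter) and the rest of the molecule drawn the same, so the configuration at that saturated ring carbon clearly counts in this cell assay. The gain from the mirror-image change can be traced to configuration alone: the fact that compounds 2 and 3 differ only in the configuration as drawn.

As far as these compounds go, the values of compound 1 and compound 2 are limits of the assay, so the full size of both steps stays unknown and the step between those two compounds cannot be read. Also open, from the compounds shown here alone, is whether compound 3 keeps its edge over its stereoisomers when a carboxylic acid replaces the ester, or when an amine replaces the chlorine on the aromatic ring of the amide.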